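Aryl swap on the triazole: sulfamoyl to dichloro

The source may report more compounds than this note shows. Statements on the series, on what has been measured and on what is new or still open speak of the compounds shown alone.

Going by the values given here, compound 3 `N#CC1=C(N)Oc2c(c3nc4ccccc4nc3c3ccccc23)C12C(=O)N(Cc1cnnn1-c1cccc(S(N)(=O)=O)c1)c1ccccc12` gives 38600 nM in an ADME assay on HUVEC cells (Homo sapiens) for antiproliferative activity, read by MTT assay, with a stated time of 48 h (on this read-out lower numbers stand for stronger inhibition and higher numbers for weaker inhibition), the only full number in this set. Compound 1 `N#CC1=C(N)Oc2c(c3nc4ccccc4nc3c3ccccc23)C12C(=O)N(Cc1cnnn1-c1ccc(F)cc1)c1ccccc12` returns only a limit, > 50000 nM. Compound 2 `N#CC1=C(N)Oc2c(c3nc4ccccc4nc3c3ccccc23)C12C(=O)N(Cc1cnnn1-c1ccc(N)cc1)c1ccccc12` likewise returns only a limit, > 50000 nM. The step of an at least 1.2-fold lower number from compound 1 to compound 3 (0.11 log units; that floor lies within the scatter) and the step of an at least 1.2-fold lower number from compound 2 to compound 3 (0.11 log units; that floor lies within the scatter) therefore read as floors only, and a step that the two limits leave unreadable from compound 1 to compound 2. Compound 4 `N#CC1=C(N)Oc2c(c3nc4ccccc4nc3c3ccccc23)C12C(=O)N(Cc1cnnn1-c1ccc(Cl)c(Cl)c1)c1ccccc12` is reached by 3,4-dichlorophenyl in place of 3-sulfamoylphenyl on an aromatic nitrogen. Both earlier steps onto the 3-sulfamoylphenyl group gave at best a small gain from the limit (the limit of > 50000 nM in this assay, at which 2 of the 3 values shown sit); the change here runs the other way, toward an aryl without donors or acceptors, so compound 4 is expected to move back toward that limit, with a step of a 1.2-fold higher number from compound 3 to compound 4 (0.09 log units; within the scatter) no larger than the scatter allows to read. The estimate for compound 4 is 48000 nM, range 20000 nM to 120000 nM, with a bare limit quite likely.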

Compound 4, half-maximal inhibitory concentration: > 50000 nM
Compound 4 was reported as a limit; the forecaster's own chance of this, stated with the estimate: 55%; middle value at least 1.0-fold (0.01 log units) away from the limit.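

Compound 4 returns only a limit, > 50000 nM, so a disubstituted aryl carrying only chlorine on the aromatic nitrogen yields no full number. The swap from 3-sulfamoylphenyl to 3,4-dichlorophenyl reads as an at least 1.2-fold higher number from compound 3 to compound 4 (0.11 log units; that floor lies within the scatter), a floor only, and the steps to this compound from the two other limit compounds cannot be read. In this assay, readings at this position remain dominated by a single limit: the limit of > 50000 nM in this assay, at which 3 of the 4 values shown sit.

Still open, as far as these compounds go, is whether any aryl here can give a value clearly separated from that limit. A carboxylic acid on the phenyl ring, or a longer chain in place of the aryl, would test this.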